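The compounds below may be only part of what the source reports. "The series", "measured", "known", "first", "only" and "open" are said of these compounds alone.

Compound 1 `COc1cc([C@@H]2C[C@@]2(CO)C(=O)Nc2ccccc2)cc(OC)c1OC`: 36700 nM
Compound 2 `CCOC(=O)[C@@]1(C(=O)NCc2ccc(C)cc2)C[C@H]1c1cc(OC)c(OC)c(OC)c1`: 26400 nM
Compound 3 `CCOC(=O)[C@]1(C(=O)NCc2ccc(C)cc2)C[C@H]1c1cc(OC)c(OC)c(OC)c1`: 32100 nM

In a functional assay on QGY cells (Homo sapiens) for cytotoxicity, read by MTT assay, with a stated time of 48 h (a higher number here means a weaker inhibitor, a lower number a stronger inhibitor), compound 2 gives 26400 nM and sits within the scatter of both other compounds. Compound 4 `COc1cc([C@@H]2C[C@@]2(CO)C(=O)NCc2ccc(C)cc2)cc(OC)c1OC` has hydroxymethyl in place of ethoxycarbonyl on a saturated ring carbon. For the measured compounds named here, the one measured step, a 1.2-fold higher number from compound 2 to compound 3 (0.08 log units; within the scatter), concerns the fact that compounds 2 and 3 differ only in the configuration as drawn and so says little about this swap. Compound 1 is the nearest guide, though its amide part differs: it also carries hydroxymethyl and gives 36700 nM, within the scatter of compound 2. No change beyond the scatter is therefore expected, and the estimated 1.1-fold higher number from compound 2 to compound 4 (0.06 log units; within the scatter) stays small. Compound 4 is estimated at 30000 nM, with an expected range from 14000 nM to 65000 nM.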

Compound 4, half-maximal inhibitory concentration: 58700 nM
Compound 4: middle estimate off by 2.0-fold (0.29 log units), on the low side; the measured number falls inside the stated range.
By their numbers in this assay, from the lowest: compounds 2, 3, 1 and 4 (each within the scatter of the next, the first and the last beyond it).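

In this assay, hydroxymethyl in place of ethoxycarbonyl on a saturated ring carbon gives a 2.2-fold higher number from compound 2 to compound 4 (0.35 log units; beyond the scatter), a modest change, but the only step shown here that lies beyond the scatter. With hydroxymethyl kept, 4-methylbenzyl in place of phenyl on an amide-type nitrogen gives a 1.6-fold higher number from compound 1 to compound 4 (0.20 log units; within the scatter), so that amide change shows no clear effect. Nothing available explains why the swap on the ring carbon moves the number.

As far as these compounds go, whether an amine, a carboxylic acid or a longer chain on this ring carbon would give a lower or higher number remains open. Also open, from the compounds shown here alone, is whether the configuration at this carbon matters once hydroxymethyl is present.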